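A few compounds are considered here, and "the series" means these few. Any claim that something is new, unique, unknown or untested is made for them only; others in the source may bear on it.

Measured so far:
- compound 1, `O=C(C1CCC(F)(F)CC1)N1CC(c2nc(-c3cccc(Cl)c3)no2)C1` — 180 nM
- compound 2, `O=C(c1ccccc1F)N1CC[C@H]1c1nc(-c2cccc(F)c2)no1` — > 10000 nM
- compound 3, `Cc1ccc(S(=O)(=O)N2CC(c3nc(-c4cccc(Cl)c4)no3)C2)cc1` — > 10000 nM

Of the compounds shown here, three have been tested in an assay on HEK293 cells for positive allosteric modulation of metabotropic glutamate receptor 5 (Homo sapiens), read by FLIPR; a higher number here means that more compound is needed for the effect, a lower number that less compound is needed. Compound 1, `O=C(C1CCC(F)(F)CC1)N1CC(c2nc(-c3cccc(Cl)c3)no2)C1`, is the only one of them with an actual number, giving 180 nM. Compound 2, `O=C(c1ccccc1F)N1CC[C@H]1c1nc(-c2cccc(F)c2)no1`, returned only a limit of the assay, > 10000 nM. Compound 3, `Cc1ccc(S(=O)(=O)N2CC(c3nc(-c4cccc(Cl)c4)no3)C2)cc1`, likewise returned only a limit, > 10000 nM. For the measured compounds named here, because of the limit of > 10000 nM in this assay, at which 2 of the 3 values shown sit, compound 1 stands alone as the reference point, and no step between two measured compounds can be read from these three.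

The next compound, compound 4, `CC1CCN(C(=O)N2CC(c3nc(-c4cccc(Cl)c4)no3)C2)CC1`, keeps the core of compound 1 and differs in one place: 4-methylpiperidin-1-yl in place of 4,4-difluorocyclohexyl on a carbonyl carbon. Going by the values given here, with no measured step to lean on, only a modest shift in this assay is expected, most likely a small loss that may stay within the usual scatter. The expected step of a 1.9-fold higher number from compound 1 to compound 4 (0.29 log units; within the scatter) reflects this. Compound 4 is therefore estimated at 350 nM, within a range from 100 nM to 1500 nM.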

Compound 4, half-maximal effective concentration: 865 nM
Compound 4: middle estimate off by 2.5-fold (0.39 log units), on the low side, and the stated range covers the measured number.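

For the compounds shown here, this is the first step that can be read in this assay, and it shows that the group on the carbonyl carbon matters: a 4.8-fold higher number from compound 1 to compound 4 (0.68 log units; beyond the scatter). The two groups are both six-membered non-aromatic rings, and neither has a hydrogen-bond donor or acceptor, so those counts do not separate them. Even so, compound 4 still gives a measured number of 865 nM, so a ring with a nitrogen at this place keeps measurable activity, though less of it than the 4,4-difluorocyclohexyl group gives.

The swap changes the fluorines, the ring nitrogen and the methyl at once, so it remains open which of them accounts for the step, and a 4,4-difluoropiperidin-1-yl group on the same carbonyl carbon would help separate them. No other step can be read yet: the limit of > 10000 nM in this assay, at which 2 of the 4 values shown sit.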